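This account rests on a few compounds, and the source may have more. Where it says the series, first, only, none or still open, it means among the compounds named here.

Measured compounds:
compound 1 `COc1ccccc1NC(=O)Nc1cccc(CNc2nccnc2Cl)c1`: 10400 nM
compound 2 `CN(C)c1ccc(NC(=O)Nc2cccc(CNc3nccnc3Cl)c2)cc1`: 20200 nM

Both were tested in a functional assay on T-24 cells (Homo sapiens) for antiproliferative activity, read by MTT assay, with a stated time of 48 h; a lower number here means a stronger inhibitor, a higher number a weaker inhibitor. Going by the values given here, compound 2 gives the highest of the two numbers, though its only neighbour, compound 1, sits within the scatter of it, as the step of a 1.9-fold higher number from compound 1 to compound 2 (0.29 log units; within the scatter) shows. Compound 3 `Cc1ccc(NC(=O)Nc2cccc(CNc3nccnc3Cl)c2)cc1Cl` has not yet been measured. It differs from compound 2 in one place: 3-chloro-4-methylphenyl in place of 4-(dimethylamino)phenyl on an amide-type nitrogen. Among the compounds with values here, the only step that bears on this change, the swap of one aryl group on the amide-type nitrogen from compound 1 to compound 2, stayed within the scatter. Within the data shown here, the new aryl group brings no measured step of its own, so no step beyond the scatter is expected for a 1.3-fold lower number from compound 2 to compound 3 (0.13 log units; within the scatter). Compound 3 is therefore estimated at 15000 nM, with a range from 6000 nM to 40000 nM.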

Compound 3, half-maximal inhibitory concentration: 7390 nM
Estimate against measurement, compound 3: 2.0-fold (0.31 log units) above; the range from low to high includes it.
By their numbers in this assay, from the lowest: compounds 3, 1 and 2 (each within the scatter of the next, the first and the last beyond it).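

In this assay, going by these compounds alone, the group on this amide-type nitrogen can shift the number: 3-chloro-4-methylphenyl in place of 4-(dimethylamino)phenyl gives a 2.7-fold lower number from compound 2 to compound 3 (0.44 log units; beyond the scatter), the first step here beyond the scatter, though a modest one. Replacing 2-methoxyphenyl with the same group gives a 1.4-fold lower number from compound 1 to compound 3 (0.15 log units; within the scatter), so these two groups are not separated. Nothing measured here explains either result. From the compounds shown here alone, it remains open whether a ring is needed on this nitrogen at all, or whether a cyclohexyl group or a longer alkyl chain would give a similar number.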